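A few compounds are considered here, and "the series" means these few. Any claim that something is new, unique, unknown or untested is made for them only; others in the source may bear on it.

For the measured compounds named here, in a functional assay on M21 cells (Homo sapiens) for antiproliferative activity, read by sulforhodamine B assay, with a stated time of 48 h (a higher number here means a weaker inhibitor, a lower number a stronger inhibitor), compound 2 `CCCCOc1ccc(NS(=O)(=O)c2ccc(N3CCNC3=O)cc2)cc1` gives 580 nM, the only actual number so far. Compound 1 `O=C1NCCN1c1ccc(S(=O)(=O)Nc2ccc(C3CCCCC3)cc2)cc1` reaches only a limit in this assay, > 1000 nM. Compound 3 `CCCCCCOc1ccc(NS(=O)(=O)c2ccc(N3CCNC3=O)cc2)cc1` differs from compound 2 by ethyl in place of hydrogen on a saturated chain carbon, four bonds along the chain from an oxygen on an aromatic ring. Going by the values given here, the one measured step, an at least 1.7-fold lower number from compound 1 to compound 2 (0.23 log units; that floor lies within the scatter), put butoxy in place of cyclohexyl, which is a different change, so it gives no firm guide here. No shift beyond the usual scatter is therefore expected, and the estimated step is a 1.1-fold lower number from compound 2 to compound 3 (0.02 log units; within the scatter). Compound 3 is expected at 550 nM, with an estimated range of 200 nM to 1000 nM.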

Compound 3, half-maximal inhibitory concentration: > 1000 nM
Compound 3 was reported as a limit; the forecaster's own chance of this, stated with the estimate: 20%; middle value at least 1.8-fold (0.25 log units) from the limit.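

Adding ethyl at this chain carbon brings an at least 1.7-fold higher number from compound 2 to compound 3 (0.23 log units; that floor lies within the scatter) in this assay. On these data alone, the value of compound 3 is a limit, so the real size of this step is unknown, but the longer hexyloxy chain shows no gain in strength over butoxy. The step from compound 1 to compound 3 cannot be read, and limits dominate this small set: the limit of > 1000 nM in this assay, at which 2 of the 3 values shown sit.

Still open, as far as these compounds go, is how a shorter chain such as ethoxy would read in this assay, and whether an amine or a carboxylic acid at the end of the chain would shift the number.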